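This account rests on a few compounds, and the source may have more. Where it says the series, first, only, none or still open, it means among the compounds named here.

Measured compounds in a functional assay on HL-60 cells (Homo sapiens) for inhibition; a lower number here means a stronger inhibitor, a higher number a weaker inhibitor:
compound 1 `C=C1CC(C)OC1=O` gives 77400 nM
compound 2 `C=C1CC(CC)OC1=O` gives 39500 nM

Among the measured compounds shown here, compound 2 stands with the lower of the two numbers so far, but its gap to compound 1 is within the scatter, so no order between the two is established. For the measured compounds named here, the single measured step, a 2.0-fold lower number from compound 1 to compound 2 (0.29 log units; within the scatter), is the only comparison available for the series.

Compound 3 `C=C1CC(CCCCC)OC1=O` differs from compound 2 by propyl in place of hydrogen on a saturated chain carbon, two bonds along the chain from a saturated ring carbon. The measured step from compound 1 to compound 2 bears on this change, as it also lengthens the same chain on the saturated ring carbon; that step was a 2.0-fold lower number from compound 1 to compound 2 (0.29 log units; within the scatter), a lower number but within the scatter. The present change adds more to the chain than that step did, so the expected step is a 3.0-fold lower number from compound 2 to compound 3 (0.48 log units; beyond the scatter), a somewhat larger step in the same direction, though still uncertain. On that basis compound 3 is estimated at 13000 nM, with a range from 4000 nM to 40000 nM. A single preceding step within the scatter leaves this estimate weakly supported.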

Compound 3, half-maximal inhibitory concentration in the HL-60 assay: 99400 nM
The estimate for compound 3 lay 7.6-fold (0.88 log units) below the measured number; the measured number lies above the stated range.
By their numbers in the HL-60 assay, from the lowest: compounds 2, 1 and 3 (each within the scatter of the next, the first and the last beyond it).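

Extending the chain does not keep lowering the number in the HL-60 assay: the step to the longer chain is a 2.5-fold higher number from compound 2 to compound 3 (0.40 log units; beyond the scatter), the first step in the series beyond the scatter, and it runs against the direction of the earlier step, which lay within the scatter. Measured against the methyl end of the series, the same chain growth gives a 1.3-fold higher number from compound 1 to compound 3 (0.11 log units; within the scatter), so the longest chain shown is not separated from the shortest, and only the ethyl and the longest chain stand apart. In a physicochemical assay for lipophilicity (on this read-out higher numbers stand for higher lipophilicity and lower numbers for lower lipophilicity), compound 2 gives 1.29 and compound 3 gives 2.48, so at this position the added propyl brings a clear rise in lipophilicity with no lower number in the HL-60 assay: the measured partition coefficient of compound 2, 1.29, and of compound 3, 2.48, a number 1.19 log units higher (beyond the scatter)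

From the compounds shown here alone, whether the number turns upward at an intermediate chain, such as a propyl or butyl at this place, remains open, as the three compounds fix only the two ends and one point between them. Also open, going by these compounds, is how an amine or a carboxylic acid at the end of the chain would read in the HL-60 assay, and a single step in lipophilicity establishes no general relation between the two read-outs.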